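Amino for chloro on a purine core: expected cytotoxicity shift

This account rests on a few compounds, and the source may have more. Where it says the series, first, only, none or still open, it means among the compounds named here.

Compound 3 `ClCc1ccc(Cn2cnc3c(Cl)nc(Cl)nc32)cc1` and compound 1 `Nc1nc(Cl)c2ncn(Cc3ccc(CCl)cc3)c2n1` share a core and differ in one place: amino in place of chloro on an aromatic carbon. In a functional assay on HCT-116 cells (Homo sapiens) for cytotoxicity, read by sulforhodamine B assay, with a stated time of 48 h (a higher number here means that more compound is tolerated, a lower number that less compound is tolerated), compound 3 gives 7590 nM and compound 1 gives 56200 nM, a step of a 7.4-fold higher number from compound 3 to compound 1 (0.87 log units; beyond the scatter). Compound 2 `ClCc1cccc(Cn2cnc3c(Cl)nc(Cl)nc32)c1` gives 5880 nM in this assay, a value within the usual scatter of that of compound 3; the difference between the two cores is not broken down here. Compound 4 `Nc1nc(Cl)c2ncn(Cc3cccc(CCl)c3)c2n1` has not been measured. Among the compounds with values here, it differs from compound 2 by amino in place of chloro on an aromatic carbon, the same change as the one from compound 3 to compound 1, at a place described in the same words. Within the data shown here, the step to compound 4 is expected to be a 7.1-fold higher number from compound 2 to compound 4 (0.85 log units; beyond the scatter), resting on the single measured example. Compound 4 is therefore estimated at 42000 nM, with a range from 15000 nM to 115000 nM.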

Compound 4, concentration lethal to 50% of the cells: 75900 nM
Compound 4: the middle estimate sits 1.8-fold (0.26 log units) below what was measured; the measured number falls inside the stated range.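

In this assay, amino in place of chloro on an aromatic carbon gives a 13-fold higher number from compound 2 to compound 4 (1.11 log units; beyond the scatter), and the step carries over to the second core in direction and, within the scatter, in size: the same change on two cores in this assay, a 7.4-fold higher number (0.87 log units; beyond the scatter) from compound 3 to compound 1 and a 13-fold higher number (1.11 log units; beyond the scatter) from compound 2 to compound 4, 1.7-fold (0.24 log units) apart, within the scatter of two such steps. Two pairs in a single assay show that the change behaves alike on these two cores. They do not show that it would do so on any other core, and they do not say why the number goes up.

The compounds shown leave open whether a methoxy group or a methylamino group at the same place would give a step of similar size. They also leave open what an amino group would do in place of the remaining chloro group.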